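Swapping 2-chlorophenyl for 4-nitrophenyl in a growth inhibition series

This account rests on a few compounds, and the source may have more. Where it says the series, first, only, none or still open, it means among the compounds named here.

Measured so far in an ADME assay on RAW264.7 cells (Mus musculus) for inhibition, read by MTT assay, with a stated time of 72 h, tested at 100 uM (on this read-out higher numbers stand for more inhibition of growth at the one concentration tested and lower numbers for less inhibition of growth), are three compounds:

- compound 1 `O=C(N/N=C(/N=N/c1ccccc1Cl)c1ccccc1)c1cc(O)c(O)c(O)c1` gives 32.7%
- compound 2 `O=C(N/N=C(/N=N/c1ccccc1)c1ccccc1)c1cc(O)c(O)c(O)c1` gives 41.4%
- compound 3 `O=C(N/N=C(/N=N/c1ccc(F)cc1)c1ccccc1)c1cc(O)c(O)c(O)c1` gives 23.7%

Compound 1 stands apart from neither of the other two, and the data show a number 8.7 percentage points higher from compound 1 to compound 2 (within the scatter) and a number 9 percentage points lower from compound 1 to compound 3 (within the scatter) as its two steps. Among the measured compounds shown here, the only step in the set that leaves the scatter is a number 17.7 percentage points lower from compound 2 to compound 3 (beyond the scatter) and it does not involve compound 1.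

Compound 4 `O=C(N/N=C(/N=N/c1ccc([N+](=O)[O-])cc1)c1ccccc1)c1cc(O)c(O)c(O)c1` has 4-nitrophenyl in place of 2-chlorophenyl on a double-bonded nitrogen and has not yet been measured. For the measured compounds named here, the nearest precedent is the step to compound 3 (a number 9 percentage points lower from compound 1 to compound 3 (within the scatter)) which replaces the same 2-chlorophenyl and stays within the scatter. Going by the values given here, no compound with 4-nitrophenyl has been measured, so the evidence is indirect. No step beyond the scatter is therefore expected, and the expected step is a number 2.7 percentage points lower from compound 1 to compound 4 (within the scatter) on this reasoning. For compound 4 the estimated value is 30% with an expected range from 15% to 48% on this read-out.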

Compound 4, percent growth inhibition at one concentration: 34.6%
Compound 4: middle estimate off by 4.6 percentage points, on the low side; the range from low to high includes it.
By their numbers in this assay, from the lowest: compounds 3, 1, 4 and 2 (each within the scatter of the next, the first and the last beyond it).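

On a double-bonded nitrogen, 4-nitrophenyl can replace 2-chlorophenyl with no step beyond the scatter in this assay, as shown by a number 1.9 percentage points higher from compound 1 to compound 4 (within the scatter). Substituents on the same aromatic carbon do separate, however: nitro in place of fluoro gives a number 10.9 percentage points higher from compound 3 to compound 4 (beyond the scatter), the second step in the set to leave the scatter. Nitro in place of hydrogen stays within it, with a number 6.8 percentage points lower from compound 2 to compound 4 (within the scatter), so both steps beyond the scatter now involve compound 3, which is set apart from the unsubstituted and nitro compounds but not from the 2-chlorophenyl compound.

Nothing available on these compounds accounts for this difference between fluoro and nitro. The compounds shown leave open how an amine or a carboxylic acid in place of the nitro on that aromatic carbon would read on this assay.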